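Removing One Chloro Group from Compound 1

The source may hold more compounds than are shown below. What is called first, only, known or untested is meant among the compounds shown, and "the series" means these compounds.

Compound 1 `ClCc1ccc(Cn2cnc3nc(Cl)nc(Cl)c32)cc1`: 1810 nM
Compound 2 `ClCc1cccc(Cn2cnc3nc(Cl)nc(Cl)c32)c1`: 1860 nM
Compound 3 `Nc1nc(Cl)c2ncn(Cc3cccc(CCl)c3)c2n1`: 3380 nM

In a functional assay on SF-295 cells (Homo sapiens) for cytotoxicity, read by sulforhodamine B assay, with a stated time of 48 h (a lower number here means a stronger inhibitor of growth, a higher number a weaker inhibitor of growth), compound 1 gives 1810 nM, the lowest of the three numbers, yet compound 2 gives 1860 nM and compound 3 gives 3380 nM, both within the scatter of compound 1, so no order among them can be read. Compound 4 `ClCc1ccc(Cn2cnc3ncnc(Cl)c32)cc1` differs from compound 1 by hydrogen in place of chloro on an aromatic carbon. For the measured compounds named here, no measured pair shows this change directly. Compound 3, which carries an amino group and a single chloro on the core, reaches a number close to the others, which suggests that the second chloro is not decisive. A step of about the scatter, if any, is expected for compound 4, estimated as a 1.4-fold higher number from compound 1 to compound 4 (0.16 log units; within the scatter), giving 2600 nM with a range from 900 nM to 7500 nM.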

Compound 4, concentration for 50% growth inhibition: 2040 nM
For compound 4 the middle estimate is 1.3-fold (0.11 log units) above the measured one; the measured number falls inside the stated range.
By their numbers in this assay, from the lowest: compounds 1, 2, 4 and 3 (each within the scatter of the next).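

In this assay the step for hydrogen in place of chloro on the carbon between two ring nitrogen atoms is a 1.1-fold higher number from compound 1 to compound 4 (0.05 log units; within the scatter) and so this chloro can leave the core of compound 1 with no step beyond the scatter. For the compounds shown here, this is the first direct reading of this change at this position, which the earlier compounds could only hint at. Nothing measured here gives a reason for this result.

As far as these compounds go, whether a larger group at this position, such as a methoxy group or a carboxylic acid, would leave the number as little moved remains open. So does the effect of replacing the remaining chloro on the core.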